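The source may report more compounds than this note shows. Statements on the series, on what has been measured and on what is new or still open speak of the compounds shown alone.

Compound 1 `COc1ccc(N2CCN(Cc3csc(N)c3C(=O)c3ccc(Cl)cc3)CC2)cc1`: -1.2%
Compound 2 `Nc1scc(CN2CCN(c3cccc(F)c3)CC2)c1C(=O)c1ccc(Cl)cc1`: -18%

Both numbers come from a functional assay on CHO cells with adenosine receptor A1 (Homo sapiens) as the target, read by cAMP accumulation and immunoassay, with a stated time of 6 min, tested at 0.01 uM; a higher number here means a weaker effect of the compound at the concentration tested, a lower number a stronger effect. For the measured compounds named here, compound 2 stands lowest of the two; its nearest neighbour is compound 1, and the single measured step, a number 16.8 percentage points lower from compound 1 to compound 2 (beyond the scatter), separates them beyond the usual scatter. That step put a 3-fluorophenyl in place of a 4-methoxyphenyl on an amine nitrogen in a ring.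

Compound 3 `Nc1scc(CN2CCN(c3cccc(Cl)c3)CC2)c1C(=O)c1ccc(Cl)cc1` has not yet been measured. It differs from compound 2 in one place: chloro in place of fluoro on an aromatic carbon. Going by the values given here, no measured step bears on this exchange: the only step on record changed a different group on that same nitrogen, and nothing shows what swapping fluoro for chloro does here. Without such a precedent, the expectation for compound 3 is a step of a number 1 percentage points higher from compound 2 to compound 3 (within the scatter), meaning no change beyond the scatter. Compound 3 is therefore estimated at -17%, with a range from -30% to -4%.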

Compound 3, a percentage reported as activity, at one concentration (the size of the read-out at that concentration, not a potency): -3.1%
Estimate against measurement, compound 3: 13.9 percentage points below, and the stated range ends below it.
By their numbers in this assay, from the lowest: compound 2; then compounds 3 and 1 (each within the scatter of the next).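

In this assay the halogen at this place on the ring matters: chloro in place of fluoro, one heavy atom for another, gives a step beyond the scatter toward a weaker effect (a number 14.9 percentage points higher from compound 2 to compound 3 (beyond the scatter)). The other new step lies within the scatter (a number 1.9 percentage points lower from compound 1 to compound 3 (within the scatter)), so the 3-chlorophenyl and 4-methoxyphenyl groups cannot be told apart here, and among these three compounds only the 3-fluorophenyl of compound 2 stands apart. Nothing measured here explains why fluoro and chloro differ at this position.

As far as these compounds go, it remains open whether the stronger effect of compound 2 is particular to fluoro or would also appear with a bromo, methyl or nitrile group at the same place. These read-outs at one concentration also leave the potency of all three compounds open.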